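Three solubility limits and an unmeasured fourth compound

The compounds below may be only part of what the source reports. "The series", "measured", "known", "first", "only" and "open" are said of these compounds alone.

Compound 1 `CNC(=O)c1cc(Oc2ccc3nc(Nc4cccc(C(C)(C)C)c4)ccc3c2)ccn1` sits in a physicochemical assay for solubility, at pH 7 (a lower number here means a less soluble compound, a higher number a more soluble compound), at the limit < 1000 nM. Compound 2 `CNC(=O)c1cc(Oc2ccc3nc(Nc4ccccc4Br)ncc3c2)ccn1` sits in this assay at the limit < 1000 nM. Compound 3 `CNC(=O)c1cc(Oc2ccc3nc(Nc4ccccc4Oc4ccccc4)ncc3c2)ccn1` sits in this assay at the limit < 1000 nM.

Compound 2 thus stands at a limit in this assay, without a number of its own, and the two further values shown are limits as well. Going by the values given here, the single step among measured compounds that differ in one place is a step that the two limits leave unreadable from compound 2 to compound 3; its two ends are both limits, so its size cannot be read, a situation summed up by the limit of < 1000 nM in this assay, at which 3 of the 3 values shown sit. Compound 4 `CNC(=O)c1cc(Oc2ccc3nc(Nc4cccc(Cl)c4)ncc3c2)ccn1` differs from compound 2 by 3-chlorophenyl in place of 2-bromophenyl on a nitrogen on an aromatic ring. Among the compounds with values here, no measured step covers this particular exchange, and the one step that is known offers no readable size. What remains is that every measured compound, whatever its group on the nitrogen, reports the same limit in this assay. On that basis the step that the limit leaves unreadable from compound 2 to compound 4 is expected to be none beyond the scatter, with compound 4 expected to stay at or near the limit. Compound 4 is estimated at 500 nM, within a range from 100 nM to 2000 nM, and a limit rather than a number is the likelier outcome.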

Compound 4, solubility: < 1000 nM
Compound 4 was reported as a limit (the forecaster's own chance of this, stated with the estimate: 75%); the middle value does not contradict the limit.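

Going by these compounds alone, compound 2 and compound 4 are both reported only as limits in this assay, so the step between them cannot be read and no new step results: the limit of < 1000 nM in this assay, at which 4 of the 4 values shown sit.

The compounds shown leave open where any of them actually lies under that limit in this assay, and so whether exchanging the group on the nitrogen moves the value at all.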